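From 3,4-dihydroxyphenyl to phenyl in compound 1

The source may report more compounds than this note shows. Statements on the series, on what has been measured and on what is new or still open speak of the compounds shown alone.

In a functional assay, with a stated time of 30 min, in the absence of a further agent (a lower number here means a stronger inhibitor, a higher number a weaker inhibitor), compound 1 (`O=C(/C=C/c1ccc(O)c(O)c1)OCCOc1no[n+]([O-])c1S(=O)(=O)c1ccccc1`) gives 42000 nM and compound 2 (`O=C(OCCOc1no[n+]([O-])c1S(=O)(=O)c1ccccc1)c1ccc(O)c(O)c1`) gives 60000 nM as its value, so the two stand level. For the measured compounds named here, the one measured step (a 1.4-fold higher number from compound 1 to compound 2 (0.15 log units; within the scatter)) keeps the 3,4-dihydroxyphenyl and so does not test its loss. Compound 3 (`O=C(/C=C/c1ccccc1)OCCOc1no[n+]([O-])c1S(=O)(=O)c1ccccc1`) has phenyl in place of 3,4-dihydroxyphenyl on a double-bonded chain carbon bound to a double-bonded chain carbon. Going by the values given here, no measurement yet speaks to this change, so the expected step (a 1.4-fold higher number from compound 1 to compound 3 (0.15 log units; within the scatter)) is none beyond the scatter, with wide uncertainty. For compound 3 the estimated value is 60000 nM with an expected range (20000 nM to 180000 nM).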

Compound 3, half-maximal inhibitory concentration: > 10000000 nM
Compound 3 was reported as a limit (the forecaster's own chance of this, stated with the estimate: 25%); middle value at least 160-fold (2.22 log units) away from the limit.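

In this assay, compound 3 is reported only as a limit, > 10000000 nM. Phenyl in place of 3,4-dihydroxyphenyl gives an at least 230-fold higher number from compound 1 to compound 3 (2.37 log units; beyond the scatter), and 2-phenylethenyl in place of 3,4-dihydroxyphenyl on a carbonyl carbon gives an at least 160-fold higher number from compound 2 to compound 3 (2.22 log units; beyond the scatter). The inhibition seen in this small set therefore depends on the 3,4-dihydroxyphenyl, whereas the step that kept this group stayed within the scatter. From the compounds shown here alone, whether one hydroxyl group would serve as well as two remains open, as does whether methoxy groups or an amine could replace them on the ring.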